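Bromo to Chloro in a Compound at the Assay Limit

A few compounds are considered here, and "the series" means these few. Any claim that something is new, unique, unknown or untested is made for them only; others in the source may bear on it.

Of the compounds shown here, three with a shared core have been tested in a functional assay on HCT-116 cells (Homo sapiens) for antiproliferative activity, read by CCK-8 assay, with a stated time of 72 h; on this read-out higher numbers stand for weaker inhibition and lower numbers for stronger inhibition. Compound 1 `CC1=NN(c2ccc(Br)cc2)C(=O)C12C=CC(=O)C=C2c1cccc(C)c1` gave only a limit, > 100000 nM, so its true potency is known only as lying beyond that boundary. Compound 3 `CC1=NN(c2ccc(Br)cc2)C(=O)C12C=CC(=O)C=C2c1ccccc1` likewise gave only a limit, > 100000 nM. Compound 2 `CC1=NN(c2ccc(Br)cc2)C(=O)C12C=CC(=O)C=C2c1ccc(C)cc1`, which carries a 4-methylphenyl, gave a measured value of 10600 nM. The step of an at least 9.4-fold lower number from compound 1 to compound 2 (0.97 log units; beyond the scatter) shows that where the methyl sits on that ring matters, and the step of an at least 9.4-fold higher number from compound 2 to compound 3 (0.97 log units; beyond the scatter) shows that removing it matters too. The step that the two limits leave unreadable from compound 1 to compound 3 cannot be read because both compounds sit at the limit of > 100000 nM in this assay, at which 2 of the 3 values shown sit.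

Compound 4 `CC1=NN(c2ccc(Cl)cc2)C(=O)C12C=CC(=O)C=C2c1cccc(C)c1` differs from compound 1 by chloro in place of bromo on an aromatic carbon. Going by the values given here, none of the measured steps touches this halogen; every one of them concerns the methylphenyl group, so there is no direct guide to how bromo versus chloro behaves here. Among the compounds with values here, with compound 1 already standing at a limit and no step on the halogen to draw on, no change beyond the scatter is expected in this assay: a number no higher from compound 1 to compound 4 (the limit leaves the size open). Compound 4 is therefore expected to give about 100000 nM, within a range from 30000 nM to 300000 nM, and most probably again only a limit.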

Compound 4, half-maximal inhibitory concentration: 13300 nM
For compound 4 the middle estimate is 7.5-fold (0.88 log units) above the measured one, and the stated range ends above it.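

Chloro in place of bromo on the 4-bromophenyl group gives an at least 7.5-fold lower number from compound 1 to compound 4 (0.87 log units; beyond the scatter) in this assay, the first sign that the halogen counts as well as the methylphenyl group that all the earlier steps changed. As far as these compounds go, compound 1 gave > 100000 nM, which is a limit and not a number, so this step fixes only a minimum size and its true size stays unknown: the limit of > 100000 nM in this assay, at which 2 of the 4 values shown sit. Compound 1 can therefore leave the limit through either of two single changes, the halogen swap or the methyl shift seen in an at least 9.4-fold lower number from compound 1 to compound 2 (0.97 log units; beyond the scatter), which shows that a 3-methylphenyl group does not by itself rule out measurable activity.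

Chloro appears here only together with 3-methylphenyl, so it remains open whether the same swap would also lift the compound carrying plain phenyl or change the one carrying 4-methylphenyl. From the compounds shown here alone, it also remains open how this place on the ring would respond to other groups, such as fluoro, methoxy, an amine or simply hydrogen in place of the halogen.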